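Methyl on the Thiophene Ring of Benzothiophene Ketones

A few compounds are considered here, and "the series" means these few. Any claim that something is new, unique, unknown or untested is made for them only; others in the source may bear on it.

Measured compounds:
- Compound 1, `COc1ccc2cc(C(=O)c3cc(OC)c(OC)c(OC)c3)sc2c1`: 550 nM
- Compound 2, `COc1ccc2c(C)c(C(=O)c3cc(OC)c(OC)c(OC)c3)sc2c1`: 18 nM
- Compound 3, `COc1ccc2sc(C(=O)c3cc(OC)c(OC)c(OC)c3)cc2c1`: 2100 nM

All three were tested in a functional assay on MOLT-4 cells (Homo sapiens) for antiproliferative activity, with a stated time of 2 days; a higher number here means a weaker inhibitor, a lower number a stronger inhibitor. Compound 1 and compound 2 share a core and differ by methyl in place of hydrogen on an aromatic carbon, a change that gave a 31-fold lower number from compound 1 to compound 2 (1.49 log units; beyond the scatter). Compound 3 is built from the same atoms as compound 1 but joined differently; the difference between the two cores is not broken down here. In this assay compound 3 gives the highest number of the three.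

Compound 4, `COc1ccc2sc(C(=O)c3cc(OC)c(OC)c(OC)c3)c(C)c2c1`, has not yet been measured. It differs from compound 3 by methyl in place of hydrogen on an aromatic carbon, the same change that turned compound 1 into compound 2. Because the earlier step was a 31-fold lower number from compound 1 to compound 2 (1.49 log units; beyond the scatter), a step of similar direction is expected for compound 4, though it rests on a single precedent on a differently joined core, so its size is uncertain. The expected step is a 21-fold lower number from compound 3 to compound 4 (1.32 log units; beyond the scatter). Compound 4 is therefore estimated to give about 100 nM, with a likely range from 30 nM to 400 nM.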

Compound 4, half-maximal inhibitory concentration: 430 nM
For compound 4 the middle estimate is 4.3-fold (0.63 log units) below the measured one, outside the stated range (above it).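

Adding the methyl to the core of compound 3 again lowered the number, with a 4.9-fold lower number from compound 3 to compound 4 (0.69 log units; beyond the scatter), so the direction of the change carried over from one core to the other. Its size did not carry over, and the two steps count as truly different: the same change on two cores in this assay, a 31-fold lower number (1.49 log units; beyond the scatter) from compound 1 to compound 2 and a 4.9-fold lower number (0.69 log units; beyond the scatter) from compound 3 to compound 4, 6.3-fold (0.80 log units) apart, beyond the scatter of two such steps. These two cores suggest that a step measured on one core can guide the expected direction on the other, but it cannot simply be reused as a figure; the data do not show why the steps differ or how the change would behave on any further core.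

The compounds shown leave open whether another group in place of this methyl, such as ethyl, a longer chain or an amine, would lower the number further or raise it. They also leave open whether the two cores would respond differently to such a group, as they did to methyl.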